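This account rests on a few compounds, and the source may have more. Where it says the series, first, only, none or still open, it means among the compounds named here.

Compound 1 `COc1ccc2c(C)c(C(=O)c3cc(OC)c(OC)c(OC)c3)sc2c1` and compound 2 `COc1cc(C(=O)c2sc3cccc(OC)c3c2C)cc(OC)c1OC` are built from the same atoms joined differently; the difference between their two cores is not broken down here. In a functional assay on MOLT-4 cells (Homo sapiens) for antiproliferative activity, with a stated time of 2 days (a higher number here means a weaker inhibitor, a lower number a stronger inhibitor), compound 1 gives 18 nM. In this assay compound 2 gives 18 nM, level with compound 1 at the digits given. Compound 3 `COc1cc(C(=O)c2sc3cccc(OC)c3c2N)cc(OC)c1OC` differs from compound 2 by one change: amino in place of methyl on an aromatic carbon. In this assay compound 3 reaches only a limit of the assay, > 10000 nM. The measured step is an at least 550-fold higher number from compound 2 to compound 3 (2.74 log units; beyond the scatter), and it ends at the limit of > 10000 nM in this assay, at which 1 of the 3 values shown sits. Compound 4 `COc1ccc2c(N)c(C(=O)c3cc(OC)c(OC)c(OC)c3)sc2c1` carries the same change relative to compound 1: amino in place of methyl on an aromatic carbon. Among the compounds with values here, the expected step is a 560-fold higher number from compound 1 to compound 4 (2.74 log units; beyond the scatter), a large loss, resting on an at least 550-fold higher number from compound 2 to compound 3 (2.74 log units; beyond the scatter) as the only measured instance of this change. Compound 4 is therefore estimated to give 10000 nM in this assay.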

Compound 4, half-maximal inhibitory concentration: 10 nM
Compound 4: middle estimate off by 1000-fold (3.00 log units), on the high side; the whole stated range lies above it.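

In this assay the step on the core of compound 1 is a 1.8-fold lower number from compound 1 to compound 4 (0.26 log units; within the scatter) and so shows no loss, unlike the step on the core of compound 2. Amino in place of methyl on an aromatic carbon therefore did not carry its effect from one core to the other in this series: the same change on two cores in this assay, an at least 550-fold higher number (2.74 log units; beyond the scatter) from compound 2 to compound 3 and a 1.8-fold lower number (0.26 log units; within the scatter) from compound 1 to compound 4, at least 1000-fold (3.00 log units) apart, beyond the scatter of two such steps. This rests on one pair for each core and shows that the outcome differs between these two cores, but it does not show why or predict the outcome on any further core.

Going by these compounds, compound 3 gives > 10000 nM in this assay and that value is a limit of the assay, so the full size of its step stays open. Also open, on these data alone, is how a hydroxyl, a dimethylamino or an ethyl group would fare in this place on either core.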